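This account rests on a few compounds, and the source may have more. Where it says the series, first, only, none or still open, it means among the compounds named here.

Two measured compounds anchor this comparison. Compound 1 `N/C(=N\NC(=S)N1CCOCC1)c1ccccn1` gives 78.1% in a functional assay on MCF7 cells (Homo sapiens) for cytotoxicity, read by MTT assay, with a stated time of 72 h, tested at 30 uM; a lower number here means less inhibition of growth, a higher number more inhibition of growth at the concentration tested. Compound 2 `Cc1cccc(/C(N)=N/NC(=S)N2CCSCC2)n1` gives 38.6% in this assay, the lower of the two numbers, and the gap to compound 1 lies beyond the usual scatter. Compound 1 and compound 2 differ in more than one place. Among the measured compounds shown here, their two values show only that the pair as a whole sits far apart. Compound 3 `Cc1cccc(/C(N)=N/NC(=S)N2CCOCC2)n1`, not yet measured, carries the change (morpholin-4-yl in place of thiomorpholin-4-yl on a thiocarbonyl carbon), which gives it the same ring on the thiocarbonyl carbon as compound 1 while it keeps the rest of compound 2. A rise beyond the scatter is expected, since compound 1 with this ring reaches 78.1%, though compound 2 at 38.6% shows that the remaining difference also matters. The expected step is a number 17.4 percentage points higher from compound 2 to compound 3 (beyond the scatter), and compound 3 is estimated at 56%, within a range from 32% to 80%.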

Compound 3, percent growth inhibition at one concentration: 57.8%
Beside the measured number, compound 3's estimate is 1.8 percentage points below it; the measured number falls inside the stated range.
By their numbers in this assay, from the lowest: compound 2; then compound 3; then compound 1.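

In this assay the ring on the thiocarbonyl carbon now has a reading of its own: with the rest of the molecule unchanged, morpholin-4-yl in place of thiomorpholin-4-yl gives a number 19.2 percentage points higher from compound 2 to compound 3 (beyond the scatter) as the result of that one change. Compound 3 also separates out the other difference, as methyl in place of hydrogen on an aromatic carbon gives a number 20.3 percentage points lower from compound 1 to compound 3 (beyond the scatter) for that change alone, so the wide gap between compound 1 and compound 2 divides into two steps, each beyond the scatter. Nothing at hand explains why either change moves the number.

Going by these compounds, whether the ring change would give a similar step in a compound carrying hydrogen instead of methyl remains open. So does the outcome with a piperidin-1-yl ring or a dimethylamino group on the thiocarbonyl carbon, or with an ethyl group in place of the methyl.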